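The compounds below may be only part of what the source reports. "The series", "measured", "known", "first", "only" and "open" are said of these compounds alone.

Measured so far:
- compound 1 `O=C(O)c1ccc(-c2nn(Cc3ccccc3)c3ccccc23)cc1`: > 10000 nM
- compound 2 `OCc1ccc(-c2nn(Cc3ccccc3)c3ccccc23)cc1`: > 10000 nM

In a functional assay on cells (Platelet, Homo sapiens) for inhibition (on this read-out higher numbers stand for weaker inhibition and lower numbers for stronger inhibition), compound 2 gives > 10000 nM, which is a limit and not a number. Compound 1 gives > 10000 nM, likewise a limit. Together these amount to the limit of > 10000 nM in this assay, at which 2 of the 2 values shown sit.

Compound 3 `CO/N=C\c1ccc(-c2nn(Cc3ccccc3)c3ccccc23)cc1` carries the change (a group of 4 heavy atoms (2 carbon, 1 nitrogen, 1 oxygen; no ring) in place of a group of 2 heavy atoms (1 carbon, 1 oxygen; no ring), on an aromatic carbon), para to a large group. Among the compounds with values here, the only measured step bearing on it, at the same aromatic carbon, is a step that the two limits leave unreadable from compound 1 to compound 2, so it offers no size or direction. In this assay no clear move is therefore expected, and the expected step is a step that the limit leaves unreadable from compound 2 to compound 3. Compound 3 is estimated at 15000 nM, with an expected range of 4000 nM to 50000 nM.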

Compound 3, half-maximal inhibitory concentration: > 10000 nM
Compound 3 was reported as a limit (the forecaster's own chance of this, stated with the estimate: 75%); the middle value is on the limit's open side.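

No step can be read among compound 1, compound 2 and compound 3 in this assay, as each value is a limit and not a number: the limit of > 10000 nM in this assay, at which 3 of the 3 values shown sit.

The compounds shown leave open whether any group at this aromatic carbon gives measurable inhibition.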